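Indoline nitrogen capping in a pyrimidine-amine series

This account rests on a few compounds, and the source may have more. Where it says the series, first, only, none or still open, it means among the compounds named here.

Measured so far:
compound 1 `Cc1cnc(Nc2ccc3c(c2)CCN3S(=O)(=O)c2ccc(C(F)(F)F)cc2)nc1-c1cnn(C2CC2)c1` — 335 mL.min-1.g-1
compound 2 `N#CCCn1cc(-c2nc(Nc3ccc4c(c3)CCN4)ncc2F)cn1` — 436 mL.min-1.g-1
compound 3 `N#CCCn1cc(-c2nc(Nc3ccc4c(c3)CNC4=O)ncc2F)cn1` — 24.4 mL.min-1.g-1

In an ADME assay on microsomes from liver (Homo sapiens) for metabolic stability (a higher number here means faster removal of the compound, a lower number slower removal), compound 2 gives the highest of the three numbers. Compound 1 lies close to it, within the scatter, so the two show no order. For the measured compounds named here, compound 3 lies far lower, beyond the scatter; no single-point step joins it to compound 2, so only the two values are noted. Compound 4 `N#CCCn1cc(-c2nc(Nc3ccc4c(c3)CCN4C(=O)c3ccc(C(F)(F)F)cc3)ncc2F)cn1` differs from compound 2 by (4-(trifluoromethyl)phenyl)carbonyl in place of hydrogen on a nitrogen on an aromatic ring in a ring. Compound 1, which also carries a trifluoromethylphenyl group, gives 335 mL.min-1.g-1 in this assay and sits level with compound 2. On that basis the step from compound 2 to compound 4 is expected to be a 1.5-fold lower number from compound 2 to compound 4 (0.16 log units; within the scatter), within the scatter or leaning slightly lower. Compound 4 is estimated at 300 mL.min-1.g-1, range 120 mL.min-1.g-1 to 700 mL.min-1.g-1.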

Compound 4, intrinsic clearance in microsomes: 80.8 mL.min-1.g-1
The estimate for compound 4 lay 3.7-fold (0.57 log units) above the measured number; measured number below the stated range.
By their numbers in this assay, from the lowest: compound 3; then compound 4; then compounds 1 and 2 (each within the scatter of the next).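

In this assay, for the compounds shown here, the nitrogen on an aromatic ring in a ring proves sensitive to substitution: (4-(trifluoromethyl)phenyl)carbonyl in place of hydrogen gives a 5.4-fold lower number from compound 2 to compound 4 (0.73 log units; beyond the scatter), the first single-place step and one beyond the scatter. Nothing available bears on why the number falls. The compounds shown leave open whether the carbonyl or the trifluoromethyl-bearing phenyl ring accounts for the step; an acetyl group on the same nitrogen would separate the two.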